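The compounds below may be only part of what the source reports. "The series", "measured", "known", "first", "only" and "open" are said of these compounds alone.

Three selenium-bearing analogues on the shared core have been run in a functional assay on HT-29 cells (Homo sapiens) for cytotoxicity, read by MTT assay, with a stated time of 72 h; on this read-out higher numbers stand for weaker inhibition of growth and lower numbers for stronger inhibition of growth. Compound 1 `CCCCC[Se]c1nc(NCc2ccc(SC)cc2)c2ccccc2n1` reaches only the limit of the assay, > 100000 nM. Compound 2 `CCCCC[Se]c1nc([Se]CCCCC)c2ccccc2n1` likewise sits at the limit, > 100000 nM. Compound 3 `CSc1ccc(CNc2nc([SeH])nc3ccccc23)cc1`, the starting point of the present step, also sits at the limit, > 100000 nM. Among the compounds with values here, the single one-point step, a step that the two limits leave unreadable from compound 1 to compound 3, is therefore unreadable in size, and all three values fall on (the limit of > 100000 nM in this assay, at which 3 of the 3 values shown sit). Compound 4 `[SeH]c1nc(NCc2ccccc2)c2ccccc2n1` differs from compound 3 by hydrogen in place of methylsulfanyl on an aromatic carbon. Within the data shown here, no measured step reads on this change; the one step available gives neither size nor direction. With every measured neighbour at the limit, compound 4 is expected to remain there as well, so a step that the limit leaves unreadable from compound 3 to compound 4 is expected to be no step beyond the scatter. Compound 4 is estimated at 200000 nM, within 80000 nM to 1000000 nM.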

Compound 4, concentration for total growth inhibition: > 100000 nM
Compound 4 was reported as a limit; the forecaster's own chance of this, stated with the estimate: 90%; the middle value does not contradict the limit.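

Compound 3 and compound 4 both stand as limits, so no step between them can be read: the limit of > 100000 nM in this assay, at which 4 of the 4 values shown sit.

The compounds shown leave open which change on the shared core, if any, would bring a measurable inhibition of growth.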